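This account rests on a few compounds, and the source may have more. Where it says the series, first, only, none or still open, it means among the compounds named here.

In a functional assay on the whole organism for inhibition, with Brassica rapa subsp. chinensis as the target, with a stated time of 3 days, tested at 100 ppm (a higher number here means more inhibition of growth at the concentration tested, a lower number less inhibition of growth), compound 1 `CC(C)OC(=O)/C=C/c1ccccc1` gives 2%, compound 2 `CCCNC(=O)/C=C/c1ccccc1` gives 15%, and compound 3 `CCCOC(=O)/C=C/c1ccccc1` gives 31%. Compound 3 thus stands highest of the three, beyond the scatter from both others: a number 16 percentage points higher from compound 2 to compound 3 (beyond the scatter) and a number 29 percentage points higher from compound 1 to compound 3 (beyond the scatter). Compound 4 `CCCCOC(=O)/C=C/c1ccccc1` differs from compound 3 by methyl in place of hydrogen on a saturated chain carbon, three bonds along the chain from an oxygen next to a carbonyl group. Going by the values given here, no measured step lengthens a chain; the nearest is a number 29 percentage points higher from compound 1 to compound 3 (beyond the scatter), where the change likewise sits on an oxygen next to a carbonyl group and reads propyl in place of isopropyl. On that basis a further modest rise, or none beyond the scatter, is expected for compound 4 in this assay, with an estimated step of a number 7 percentage points higher from compound 3 to compound 4 (within the scatter). Compound 4 is therefore estimated at 38%, ranging from 15% to 65%.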

Compound 4, percent growth inhibition at one concentration: 5%
Compound 4: the middle estimate sits 33 percentage points above what was measured; measured number below the stated range.
By their numbers in this assay, from the lowest: compounds 1, 4 and 2 (each within the scatter of the next, the first and the last beyond it); then compound 3.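

In this assay, the rise seen with propyl on the oxygen next to a carbonyl group does not continue along the chain: the added methyl gives a number 26 percentage points lower from compound 3 to compound 4 (beyond the scatter), so the effect of chain length at this position is not a steady one. The butyl compound falls in with the others, with a number 10 percentage points lower from compound 2 to compound 4 (within the scatter) and a number 3 percentage points higher from compound 1 to compound 4 (within the scatter) as its steps. Nothing available here accounts for this drop.

On these data alone, whether an ethyl group or a chain longer than butyl on that oxygen would read high or low remains open. So does whether butylamino in place of butoxy would follow the same course, since the amide side rests on compound 2 alone.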